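The source may report more compounds than this note shows. Statements on the series, on what has been measured and on what is new or still open speak of the compounds shown alone.

In a functional assay on LNCaP cells (Homo sapiens) for antiproliferative activity, read by propidium iodide staining, with a stated time of 96 h (on this read-out higher numbers stand for weaker inhibition and lower numbers for stronger inhibition), compound 1 (`CC(O)(CSc1ccc(S(F)(F)(F)(F)F)cc1)C(=O)Nc1ccc([N+](=O)[O-])c(C(F)(F)F)c1`) gives 8700 nM and compound 2 (`CC(O)(CSc1ccc(C(F)(F)F)cn1)C(=O)Nc1ccc(S(F)(F)(F)(F)F)cc1`) gives 12300 nM on the same scale. Compound 3 (`CC(O)(CSc1ccc(F)cc1)C(=O)Nc1cccc(S(F)(F)(F)(F)F)c1`) gives 26900 nM in that test. This is the highest of the three numbers and lies beyond the usual scatter from both of the others, so compound 3 is the weakest inhibitor of the group.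

No two of these compounds differ in one place only, so the data contain no measured step that shows what a single change does. Compound 4 (`CC(O)(CSc1ccccc1C(F)(F)F)C(=O)Nc1cccc(S(F)(F)(F)(F)F)c1`) has not yet been tested. It has 2-(trifluoromethyl)phenyl in place of 4-fluorophenyl on a sulfur and otherwise matches compound 3.

Among the compounds with values here, with no measured step as a guide, the expectation in this assay is for no step beyond the scatter, and no direction can be firmly predicted. The closest reference is compound 3 at 26900 nM on this read-out, so the estimate stays close to that number. The estimated change is small, running a 1.2-fold lower number from compound 3 to compound 4 (0.09 log units; within the scatter) on the numbers expected here. For compound 4 the expected value is 22000 nM with an estimated range from 9000 nM to 50000 nM in this cell test.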

Compound 4, half-maximal inhibitory concentration: 12300 nM
Compound 4: middle estimate off by 1.8-fold (0.25 log units), on the high side; the measured number falls inside the stated range.
By their numbers in this assay, from the lowest: compounds 1, 2 and 4 (each within the scatter of the next); then compound 3.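

Within the data shown here, this is the first measured step in the set that isolates a single change: in this assay, with the rest of the molecule held fixed, 2-(trifluoromethyl)phenyl in place of 4-fluorophenyl on a sulfur gives a 2.2-fold lower number from compound 3 to compound 4 (0.34 log units; beyond the scatter). The group on this sulfur therefore matters to the read-out, since replacing it moves the number beyond the usual scatter, though only modestly, and in the direction of stronger inhibition. No measurement here accounts for this shift, so the step records what happens but offers no explanation for it.

The swap changes both the kind of group on the ring and the place named for it, so the compounds shown leave open which of the two matters; 2-fluorophenyl and 4-(trifluoromethyl)phenyl on the same sulfur would pull these apart. Going by these compounds, it also remains open how a ring carrying an amine or a carboxylic acid would fare at this position, and whether the same swap would give a similar step on the cores of compound 1 and compound 2.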